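Bromo for Methyl on a Sulfonamide Aryl Ring

The compounds below may be only part of what the source reports. "The series", "measured", "known", "first", "only" and "open" are said of these compounds alone.

The compounds share the core of compound 1 `Cc1cccc(S(=O)(=O)N2CCC(N3CCC(C)CC3)CC2)c1`. In an ADME assay on HCT-116 cells (Homo sapiens) for cytotoxicity, read by CellTiter-Glo, with a stated time of 72 h (a higher number here means a weaker inhibitor, a lower number a stronger inhibitor), compound 1 gives > 5000 nM, which is a limit of the assay rather than a number. Compound 2 `Cc1ccc(C#N)c(S(=O)(=O)N2CCC(N3CCC(C)CC3)CC2)c1` gives > 5000 nM in this assay, also a limit. Compound 3 `Cc1cc(C)c(S(=O)(=O)N2CCC(N3CCC(C(C)C)CC3)CC2)c(C)c1` gives > 5000 nM in this assay, again a limit. Among the measured compounds shown here, the single counted step in this assay, a step that the two limits leave unreadable from compound 1 to compound 2, therefore has no readable size. What the three values have in common is the limit of > 5000 nM in this assay, at which 3 of the 3 values shown sit.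

Compound 4 `CC1CCN(C2CCN(S(=O)(=O)c3cccc(Br)c3)CC2)CC1` differs from compound 1 in one place: bromo in place of methyl on an aromatic carbon. For the measured compounds named here, no measured step exchanges a methyl for a bromo, so none bears directly on this change, and the one step that is counted is unreadable. Because all three measured compounds sit at the limit of > 5000 nM in this assay, at which 3 of the 3 values shown sit, the expected step is a step that the limit leaves unreadable from compound 1 to compound 4, within the scatter and without direction. Compound 4 is expected to give about 9000 nM in this assay, within 3000 nM to 30000 nM, and most probably to be reported again only as a limit.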

Compound 4, half-maximal inhibitory concentration: > 5000 nM
Compound 4: no number, only a limit; the forecaster's own chance of this, stated with the estimate: 80%; the middle value is on the limit's open side.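

Among the compounds shown here, no step from compound 1 to compound 4 can be read, because both are reported only as limits: (the limit of > 5000 nM in this assay, at which 4 of the 4 values shown sit). The compounds shown leave open whether, in this assay, bromo and methyl on this ring differ at all, and at what concentration any of these compounds would reach half-maximal inhibition.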